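One Amide Substituent Changed, One Number to Go On

The source may report more compounds than this note shows. Statements on the series, on what has been measured and on what is new or still open speak of the compounds shown alone.

Three compounds sharing one core went into a functional assay on MCF7 cells (Homo sapiens) for cytotoxicity, read by MTT assay, with a stated time of 72 h; on this read-out lower numbers stand for stronger inhibition and higher numbers for weaker inhibition: compound 1 `N[C@H]1CC[C@H](Nc2c(C(=O)NCc3ccco3)nc(Br)c3cccnc23)CC1`, compound 2 `N[C@H]1CC[C@H](Nc2c(C(=O)NCc3ccc(Cl)cc3)nc(Br)c3cccnc23)CC1` and compound 3 `N[C@H]1CC[C@H](Nc2c(C(=O)NCc3cccs3)nc(Br)c3cccnc23)CC1`. The entry for compound 1 reads "not determined" (no result reported), and the entry for compound 2 reads "not determined" (no result reported). Among the compounds with values here, only one number therefore exists: in this assay compound 3 gives 7300 nM, and it has no measured neighbour to be ranked against.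

Compound 4 `N[C@H]1CC[C@H](Nc2c(C(=O)NC3CCCCC3)nc(Br)c3cccnc23)CC1` has yet to be measured. It carries cyclohexyl in place of (thiophen-2-yl)methyl on an amide-type nitrogen. Within the data shown here, no measured pair shows what such an exchange does, so the expectation rests solely on compound 3 at 7300 nM and is correspondingly loose. The expected step of a 1.1-fold higher number from compound 3 to compound 4 (0.04 log units; within the scatter) is none beyond the scatter, with neither direction favoured. For compound 4 the estimated value is 8000 nM, with an expected range from 2500 nM to 25000 nM.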

Compound 4, half-maximal inhibitory concentration: 5200 nM
Compound 4: middle estimate off by 1.5-fold (0.19 log units), on the high side; the measured number falls inside the stated range.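

Exchanging the substituent on the amide-type nitrogen gives a 1.4-fold lower number from compound 3 to compound 4 (0.15 log units; within the scatter) in this assay, so the two compounds cannot be told apart on this read-out. In this single pair, the position accepts cyclohexyl, a non-aromatic ring of carbon only, in place of (thiophen-2-yl)methyl, whose aromatic ring and sulfur are therefore not needed to keep the number at this level. No measurement at hand offers an explanation for this result.

Steps involving compound 1 or compound 2 cannot be read, since neither has a number. As far as these compounds go, it also remains open whether an amine, a carboxylic acid or a longer carbon chain on this amide nitrogen would move the number beyond the scatter, as neither cyclohexyl nor (thiophen-2-yl)methyl speaks to those groups.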